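Aryl swaps at the ring-nitrogen-flanking position of a pyridinol series

This account rests on a few compounds, and the source may have more. Where it says the series, first, only, none or still open, it means among the compounds named here.

Measured so far:
Compound 1, `Oc1cccc(-c2cc(-c3ccccc3)cc(-c3ccccc3)n2)c1`: 19300 nM
Compound 2, `Oc1cccc(-c2cc(-c3ccccc3)cc(-c3cccs3)n2)c1`: 18100 nM
Compound 3, `Oc1cccc(-c2cc(-c3ccccc3)cc(-c3ccsc3)n2)c1`: 12100 nM

All three compounds share one core and differ only in the group carried on an aromatic carbon. In a functional assay on MDA-MB-231 cells (Homo sapiens) for cytotoxicity, read by ELISA, with a stated time of 2 days (a higher number here means a weaker inhibitor, a lower number a stronger inhibitor), compound 1 gives 19300 nM, compound 2 gives 18100 nM and compound 3 gives 12100 nM. Compound 3 carries the smallest of the three numbers, yet the step of a 1.6-fold lower number from compound 1 to compound 3 (0.20 log units; within the scatter) and the step of a 1.5-fold lower number from compound 2 to compound 3 (0.17 log units; within the scatter) both stay within the scatter, as does the step of a 1.1-fold lower number from compound 1 to compound 2 (0.03 log units; within the scatter), so the three compounds cannot be told apart on these numbers.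

Compound 4, `Oc1cccc(-c2cc(-c3ccccc3)cc(-c3ccco3)n2)c1`, is the next step from compound 3. The change is furan-2-yl in place of thiophen-3-yl on an aromatic carbon. All three measured steps bear on it, since each of them also exchanges one aromatic group for another at the same aromatic carbon, and none of them moved the number beyond the scatter. On that basis no step beyond the scatter is expected in this assay for compound 4 in either direction, and the estimate places its value close to that of compound 3. For compound 4 the expected value in this assay is 14000 nM, with a range from 7000 nM to 28000 nM. This corresponds to an expected step of a 1.2-fold higher number from compound 3 to compound 4 (0.06 log units; within the scatter).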

Compound 4, half-maximal inhibitory concentration: 13700 nM
Compound 4: middle estimate off by 1.0-fold (0.01 log units), on the high side; measured number inside the range.
By their numbers in this assay, from the lowest: compounds 3, 4, 2 and 1 (each within the scatter of the next).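

In this assay, a 1.1-fold higher number from compound 3 to compound 4 (0.05 log units; within the scatter) and a 1.3-fold lower number from compound 2 to compound 4 (0.12 log units; within the scatter) and also a 1.4-fold lower number from compound 1 to compound 4 (0.15 log units; within the scatter) together show that furan-2-yl, which brings oxygen as the hetero atom of the five-membered aromatic ring where both thiophenes carry sulfur, cannot be told apart from any of the three earlier groups. The set of aromatic groups that leave the number within the scatter at this place, on an aromatic carbon next to the ring nitrogen, thus now spans phenyl, thiophen-2-yl, thiophen-3-yl and furan-2-yl, and none of the four compounds goes against this. No measurement at hand offers an explanation for this flat result.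

On these data alone, whether a group of a different kind at this place, such as a primary amine, a carboxylic acid or a morpholine ring, would move the number beyond the scatter stays open. Also open, as far as these compounds go, is how far the number depends on the 3-hydroxyphenyl group and the phenyl group, which stand unchanged in all four compounds.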